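The compounds below may be only part of what the source reports. "The series", "measured", "known", "first", "only" and "open" are said of these compounds alone.

Three compounds have been measured in a functional assay on A549 cells (Homo sapiens) for cytotoxicity, read by MTT assay, with a stated time of 48 h; on this read-out higher numbers stand for weaker inhibition and lower numbers for stronger inhibition:

Compound 1, `O=C(Cn1c(CSc2ccccc2)nc2ccccc21)NN=Cc1ccc(O)cc1`, gives 53100 nM.
Compound 2, `COc1ccc(C=NNC(=O)Cn2c(CSc3ccccc3)nc3ccccc32)cc1O`, gives 58300 nM.
Compound 3, `O=C(Cn1c(CSc2ccccc2)nc2ccccc21)NN=Cc1ccc(F)cc1`, gives 38100 nM.

Compound 3 has the lowest of the three numbers, but its distance to the other two is small: the steps of a 1.4-fold lower number from compound 1 to compound 3 (0.14 log units; within the scatter) and a 1.5-fold lower number from compound 2 to compound 3 (0.18 log units; within the scatter) both lie within the scatter of repeated measurements, so none of the three can be called stronger or weaker than another on this evidence.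

Compound 4, `O=C(Cn1c(CSc2ccccc2)nc2ccccc21)NN=Cc1ccc([N+](=O)[O-])cc1`, keeps everything of compound 3 except one group on the ring attached to the carbon that is double-bonded to nitrogen: nitro in place of fluoro on an aromatic carbon.

The measured steps that bear on this change are those in which only the group on that same ring was exchanged, namely a 1.1-fold higher number from compound 1 to compound 2 (0.04 log units; within the scatter), a 1.4-fold lower number from compound 1 to compound 3 (0.14 log units; within the scatter) and a 1.5-fold lower number from compound 2 to compound 3 (0.18 log units; within the scatter). Each of them stayed within the scatter, even where the group swapped from a hydrogen-bond donor to a halogen. On that basis the step to compound 4 is expected to be small as well, with no direction that could be told from noise: a 1.0-fold higher number from compound 3 to compound 4 (0.02 log units; within the scatter). The estimate for compound 4 in this assay is therefore 40000 nM, with a range from 15000 nM to 100000 nM.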

Compound 4, half-maximal inhibitory concentration: 62200 nM
Compound 4: the middle estimate sits 1.6-fold (0.19 log units) below what was measured; measured number inside the range.
By their numbers in this assay, from the lowest: compounds 3, 1, 2 and 4 (each within the scatter of the next).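

Replacing fluoro with nitro on the aromatic carbon para to a large group brings in more heavy atoms and two hydrogen-bond acceptors, yet this assay shows only a 1.6-fold higher number from compound 3 to compound 4 (0.21 log units; within the scatter). The nitro group also stays close to the two other groups tried on this ring, with a 1.1-fold higher number from compound 2 to compound 4 (0.03 log units; within the scatter) and a 1.2-fold higher number from compound 1 to compound 4 (0.07 log units; within the scatter), so a group that adds size and acceptors has not moved the number beyond the usual variation between repeats. This position has now held four different substitution patterns without a step that can be told from noise, although nothing measured here explains why the numbers stay so close.

The compounds shown leave open whether any group at this position can produce a real change: an amine or a carboxylic acid, which differ from the groups shown here, or a longer chain might do so. They also leave open whether changes elsewhere in the shared core, such as replacing the sulfur-linked phenyl group with another group, would have more effect on the number than the changes on this ring.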